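A few compounds are considered here, and "the series" means these few. Any claim that something is new, unique, unknown or untested is made for them only; others in the source may bear on it.

Compound 1 `CNC(=O)c1ccc2noc(-c3ccccc3)c2c1`, compound 2 `O=C(O)c1ccc2noc(-c3ccc(N4CCCCC4)cc3)c2c1` and compound 3 `O=C(O)c1ccc2noc(-c3ccc(Oc4ccccn4)cc3)c2c1` share one core and were tested in an assay for inhibition of inositol hexakisphosphate kinase 3 (Homo sapiens), read by colorimetric assay, coupled enzyme assay and malachite green, with a stated time of 120 min, in the presence of a further agent that is not named here; on this read-out higher numbers stand for weaker inhibition and lower numbers for stronger inhibition. Compound 1 gives 6830 nM, compound 2 gives 1790 nM and compound 3 gives 2060 nM. Among these three numbers compound 3 sits second highest, close to compound 2 within the usual scatter and clearly apart from compound 1. Compound 4 `O=C(O)c1ccc2noc(-c3ccc(NC(=O)C4CCCC4)cc3)c2c1` has not yet been measured; it differs from compound 3 in one place: (cyclopentylcarbonyl)amino in place of (pyridin-2-yl)oxy on an aromatic carbon. For the measured compounds named here, the only comparable step, a 1.2-fold higher number from compound 2 to compound 3 (0.06 log units; within the scatter), also exchanged the group on that aromatic carbon and changed little. A similar outcome is therefore expected, namely a 1.1-fold lower number from compound 3 to compound 4 (0.06 log units; within the scatter). Compound 4 is thus estimated to give 1800 nM in this assay, within a range from 700 nM to 4500 nM.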

Compound 4, half-maximal inhibitory concentration: 240 nM
Compound 4: middle estimate off by 7.5-fold (0.88 log units), on the high side; measured number outside the range, below it.
By their numbers in this assay, from the lowest: compound 4; then compounds 2 and 3 (each within the scatter of the next); then compound 1.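

At this aromatic carbon, para to a large group, swapping piperidin-1-yl for (pyridin-2-yl)oxy had changed little, yet the position is not indifferent to its substituent: in this assay (cyclopentylcarbonyl)amino gives an 8.6-fold lower number from compound 3 to compound 4 (0.93 log units; beyond the scatter) and a 7.5-fold lower number from compound 2 to compound 4 (0.87 log units; beyond the scatter). Unlike (pyridin-2-yl)oxy, the new group has a hydrogen-bond donor and a non-aromatic ring of carbon only, but these compounds cannot show which feature matters. No available evidence explains the gain. As far as these compounds go, whether acetylamino or benzoylamino would give a similar gain remains open.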